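The source may report more compounds than this note shows. Statements on the series, on what has been measured and on what is new or still open speak of the compounds shown alone.

Of the compounds shown here, two from this set have been measured. Compound 1 `C[C@@H]1O[C@@H](C[N+](C)(C)C)C[C@H]1F` gives 0.92 in a functional assay with muscarinic acetylcholine receptor M3 (Cavia porcellus) as the target (on this read-out higher numbers stand for larger maximal responses and lower numbers for smaller maximal responses), and compound 2 `C[C@@H]1O[C@H](C[N+](C)(C)C)C[C@@H]1F` gives 0.98 in this assay. The pair share all atoms and bonds, and the step a number 0.060 higher from compound 1 to compound 2 (within the scatter) lies within the scatter; the only thing separating them is the fact that compounds 1 and 2 differ only in the configuration as drawn. For the measured compounds named here, on the numbers so far compound 2 holds the nominally larger of the two values, with compound 1 nearest, but the gap between them is too small to rank them.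

Compound 3 `C[C@@H]1O[C@@H](C[N+](C)(C)C)C[C@@H]1F` is the next member. It differs from compound 2 in this way: the two compounds have the same atoms and bonds and differ only in configuration as drawn: 1 of 3 stereo elements differ; a stereocentre at a saturated ring carbon is drawn S in compound 2 and R in compound 3. Going by the values given here, the one measured step that bears on such a change is the configurational step from compound 1 to compound 2, which stayed within the scatter. With nothing else to go on, the configurational change in compound 3 is expected to leave this assay essentially unchanged, and the expected step is a number 0.050 lower from compound 2 to compound 3 (within the scatter). Compound 3 is therefore estimated to give 0.93 in this assay, with a likely range from 0.8 to 1.02.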

Compound 3, intrinsic activity: the largest response reached, as a fraction of the reference agonist's: 0.98
Compound 3: the middle estimate sits 0.050 below what was measured; low and high end bracket the measured number.
By their numbers in this assay, from the lowest: compounds 1, 2 and 3 (each within the scatter of the next).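

For the compounds shown here, until this point the only configurational step on record changed two stereo elements at once, whereas these pairs show single stereocentres at two different saturated ring carbons. In this assay the step at one centre is no change at the digits printed from compound 2 to compound 3 (within the scatter), and the step at the other is a number 0.060 higher from compound 1 to compound 3 (within the scatter). Neither single-centre step lies beyond the scatter, so on this read-out the maximal response tolerates the drawn configuration at each of these two centres taken alone, and the three compounds cannot be ranked, with configuration as the only difference in each pair: the fact that compounds 1 and 3 differ only in the configuration as drawn

From the compounds shown here alone, the third stereo element is drawn the same way in all three compounds, so what its inversion would do to the maximal response remains open, and a read-out of maximal response says nothing about the concentration needed to reach it. Also open, going by these compounds, is whether this tolerance would survive a change of atoms rather than of configuration, such as a hydroxyl group or a chlorine atom in place of the fluorine, or an ethyl group in place of the methyl.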